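The compounds below may be only part of what the source reports. "The series", "measured", "known", "first", "only" and "open" are said of these compounds alone.

Measured compounds:
compound 1 `N#Cc1cccc(C(=O)NC2CCCC(NC(=O)c3ccccn3)C2)c1` — 531 nM
compound 2 `CN(C)c1cccc(C(=O)N[C@H]2CCC[C@H](NC(=O)c3cccc(Cl)c3)C2)c1` — > 10000 nM

In a functional assay on HEK293 cells for antagonist activity at metabotropic glutamate receptor 5 (Homo sapiens), read by FLIPR and calcium flux (a lower number here means a stronger inhibitor, a higher number a weaker inhibitor), compound 1 gives 531 nM. For compound 2 this assay reports only a limit, > 10000 nM, so no number stands for it; it sits at the limit of > 10000 nM in this assay, at which 1 of the 2 values shown sits. Of the two measured values, compound 2 therefore occupies the weak end and compound 1 the only measured point. For the measured compounds named here, no single-change pair exists between compound 1 and compound 2, so the two values show only that one gives a number and the other none.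

Compound 3 `O=C(N[C@H]1CCC[C@H](NC(=O)c2ccccc2F)C1)c1cccc(Cl)c1` has not yet been run in this assay. Relative to compound 2 the change is 2-fluorophenyl in place of 3-(dimethylamino)phenyl on a carbonyl carbon, while the rest of the core and the other amide are kept.

Without a measured step for this change, the expectation rests on compound 1 giving 531 nM with two aromatic amides on the same core, which shows the core can reach a number in this assay. Compound 3 is expected to move from the limit toward a measurable value, a step of an at least 4.0-fold lower number from compound 2 to compound 3 (0.60 log units; beyond the scatter) in the stronger direction, though a limit remains possible. The estimate for compound 3 is 2500 nM, within 400 nM to 10000 nM.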

Compound 3, half-maximal inhibitory concentration: 175 nM
For compound 3 the middle estimate is 14-fold (1.15 log units) above the measured one; measured number outside the range, below it.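

In this assay, 2-fluorophenyl in place of 3-(dimethylamino)phenyl on a carbonyl carbon whose other neighbour is an amide-type nitrogen gives an at least 57-fold lower number from compound 2 to compound 3 (1.75 log units; beyond the scatter). This is the only single-place step among the compounds shown, and it establishes that the group at this position alone can separate a compound with a measurable value from one without. The true size of the step remains unknown and the printed figure is only a floor, because compound 2 is recorded at a limit rather than a number: the limit of > 10000 nM in this assay, at which 1 of the 3 values shown sits.

The step replaces one substituted ring with another, so it cannot show whether the change in this assay follows from losing the dimethylamino group or gaining the fluorine; an unsubstituted phenyl on the same carbonyl carbon would separate these two contributions. On these data alone, compound 1 differs from compound 3 in more than one place, so the role of the group on the other amide also stays open, and a single change there, such as a pyridine ring in an otherwise unchanged compound 3, would address it.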